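This account rests on a few compounds, and the source may have more. Where it says the series, first, only, none or still open, it means among the compounds named here.

Compound 3 `Nc1cccc(/C=C2\SC(=O)N(Cc3ccc(F)cc3)C2=O)c1` stands highest of the three numbers measured in a functional assay on L1210 cells (Mus musculus) for cytotoxicity, read by cell counting, with a stated time of 2 days; on this read-out lower numbers stand for stronger inhibition and higher numbers for weaker inhibition: compound 3 gives 142000 nM, while compound 2 `Nc1ccc(/C=C2\SC(=O)N(Cc3ccc(Cl)cc3)C2=O)cc1` gives 37000 nM and compound 1 `C=C(Br)C(=O)Nc1cccc(/C=C2\SC(=O)N(Cc3ccc(Cl)cc3)C2=O)c1` gives 940 nM, both gaps beyond the scatter. Compound 4 `Nc1cccc(/C=C2\SC(=O)N(Cc3ccc(Cl)cc3)C2=O)c1` has not been measured in this assay. It differs from compound 3 by a single change (chloro in place of fluoro on an aromatic carbon), at an aromatic carbon of a six-membered aromatic ring of carbon only. Within the data shown here, no measured pair shows this change by itself, so its size is not known here. The value of compound 4 in this assay is expected at 70000 nM, between 25000 nM and 200000 nM. The step from compound 3 to compound 4 is estimated as a 2.0-fold lower number from compound 3 to compound 4 (0.31 log units; beyond the scatter), a modest move toward stronger inhibition.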

Compound 4, half-maximal inhibitory concentration: 218000 nM
The estimate for compound 4 lay 3.1-fold (0.49 log units) below the measured number; the whole stated range lies below it.
By their numbers in this assay, from the lowest: compound 1; then compound 2; then compounds 3 and 4 (each within the scatter of the next).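

In this assay, chloro in place of fluoro on this aromatic carbon gives a 1.5-fold higher number from compound 3 to compound 4 (0.19 log units; within the scatter) and so does not separate the two compounds at this position. The other two changes do separate compounds: 3-aminophenyl in place of 4-aminophenyl gives a 5.9-fold higher number from compound 2 to compound 4 (0.77 log units; beyond the scatter) and hydrogen in place of (1-bromoethenyl)carbonyl on the nitrogen gives a 230-fold higher number from compound 1 to compound 4 (2.37 log units; beyond the scatter) as the largest step here. No evidence at hand accounts for any of these steps. From the compounds shown here alone, whether bromo or methoxy on that same aromatic carbon would read like chloro and fluoro remains open. So does whether a plain acetyl on the nitrogen would read like the (1-bromoethenyl)carbonyl of compound 1.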